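Oxazolidinone side-chain change from imidazolylmethyl to carbamoyl

The source may hold more compounds than are shown below. What is called first, only, known or untested is meant among the compounds shown, and "the series" means these compounds.

The series shares one core, carried by compound 1 `CC(=O)OC[C@H]1CN(c2ccc(-n3cc(-c4ccccn4)cn3)c(F)c2)C(=O)O1`, compound 2 `O=C1O[C@@H](Cn2ccnc2)CN1c1ccc(-n2cc(-c3ccccn3)cn2)c(F)c1` and compound 3 `O=C(NC[C@H]1CN(c2ccc(-n3cc(-c4ccccn4)cn3)c(F)c2)C(=O)O1)C(F)F`, and differs only in the group on the saturated carbon of the five-membered non-aromatic ring. In an ADME assay on HEK293-A cells (Homo sapiens) for cytotoxicity, read by MTT assay, with a stated time of 48 h (a lower number here means a stronger inhibitor, a higher number a weaker inhibitor), compound 1 gives > 400 ug/mL, a limit of the assay rather than a number. In this assay compound 2 likewise gives > 400 ug/mL, again a limit. In this assay compound 3 gives 167 ug/mL. Compound 2 therefore stands at the limit of > 400 ug/mL in this assay, at which 2 of the 3 values shown sit, so its step to compound 1, a step that the two limits leave unreadable from compound 1 to compound 2, cannot be read, while an at least 2.3-fold lower number from compound 2 to compound 3 (0.37 log units; beyond the scatter) and an at least 2.3-fold lower number from compound 1 to compound 3 (0.37 log units; beyond the scatter) show the only readable movement in the set.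

Compound 4 `NC(=O)[C@H]1CN(c2ccc(-n3cc(-c4ccccn4)cn3)c(F)c2)C(=O)O1` is not yet measured. It differs from compound 2 as follows: carbamoyl in place of (1H-imidazol-1-yl)methyl on a saturated ring carbon. Within the data shown here, no measured step changes a ring-carbon group into a carbamoyl, so the two readable steps bear on it only loosely, in that one of three variations at this position moved the number off the limit. Compound 4 is expected to stay near the limit, with a number no higher from compound 2 to compound 4 (the limit leaves the size open), and its estimated value in this assay is 400 ug/mL within a range from 150 ug/mL to 800 ug/mL.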

Compound 4, half-maximal inhibitory concentration: 152 ug/mL
Beside the measured number, compound 4's estimate is 2.6-fold (0.42 log units) above it; measured number inside the range.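

In this assay, carbamoyl on the saturated ring carbon also moves the number off the limit, with an at least 2.6-fold lower number from compound 2 to compound 4 (0.42 log units; beyond the scatter) and, where it takes the place of acetoxymethyl, an at least 2.6-fold lower number from compound 1 to compound 4 (0.42 log units; beyond the scatter). Until now only the (((difluoromethyl)carbonyl)amino)methyl group of compound 3 had done so, yet the much smaller carbamoyl gives a result that cannot be told apart from it, with a 1.1-fold lower number from compound 3 to compound 4 (0.04 log units; within the scatter), so the size of the group does not separate these two compounds. Among the compounds shown, the two groups holding an amide, in compound 3 and compound 4, lie off the limit, while the acetoxymethyl of compound 1 and the (1H-imidazol-1-yl)methyl of compound 2 remain at it: the limit of > 400 ug/mL in this assay, at which 2 of the 4 values shown sit.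

As far as these compounds go, whether this link to the amide holds stays open, since a carboxylic acid or a methyl ester on the same ring carbon, or a plain aminomethyl group, would test it. From the compounds shown here alone, how far compound 1 and compound 2 truly lie from compound 3 and compound 4 also stays open, as both of the former are known only as limits.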